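A few compounds are considered here, and "the series" means these few. Any claim that something is new, unique, unknown or untested is made for them only; others in the source may bear on it.

Working notes on the series. Compound 1 `CCn1c(C(=O)NCCN(C)C)ccc1C(CC)(CC)c1ccc(OCCC(O)(CC)CC)c(C)c1` gives the lowest number of the three measured in a functional assay on PC-3 cells (Homo sapiens) for antiproliferative activity, read by MTT assay, with a stated time of 48 h (a lower number here means a stronger inhibitor, a higher number a weaker inhibitor), at 870 nM. Compound 2 `CCn1c(C(=O)NC(C)C(=O)O)ccc1C(CC)(CC)c1ccc(OCCC(O)(CC)CC)c(C)c1` gives 11700 nM in this assay, and compound 3 `CCC(C)C(CO)NC(=O)c1ccc(C(CC)(CC)c2ccc(OCCC(O)(CC)CC)c(C)c2)n1CC` gives 28400 nM. Both measured steps away from compound 1 change the group on the amide-type nitrogen: a 13-fold higher number from compound 1 to compound 2 (1.13 log units; beyond the scatter) and a 33-fold higher number from compound 1 to compound 3 (1.51 log units; beyond the scatter), both large losses. Compound 4 `CCn1c(C(=O)N(C)CCO)ccc1C(CC)(CC)c1ccc(OCCC(O)(CC)CC)c(C)c1` differs from compound 1 at the same position: (2-hydroxyethyl)(methyl)amino in place of (2-(dimethylamino)ethyl)amino on a carbonyl carbon. Since each replacement of the 2-(dimethylamino)ethyl group so far has cost activity, as shown by a 13-fold higher number from compound 1 to compound 2 (1.13 log units; beyond the scatter) and a 33-fold higher number from compound 1 to compound 3 (1.51 log units; beyond the scatter), a loss is expected here too, though its size is uncertain with only two precedents. The estimate for compound 4 is a step of a 5.7-fold higher number from compound 1 to compound 4 (0.76 log units; beyond the scatter), giving 5000 nM with a range of 1500 nM to 16000 nM.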

Compound 4, half-maximal inhibitory concentration: 3090 nM
For compound 4 the middle estimate is 1.6-fold (0.21 log units) above the measured one; the range from low to high includes it.
By their numbers in this assay, from the lowest: compound 1; then compound 4; then compound 2; then compound 3.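

In this assay, the (2-hydroxyethyl)(methyl)amino group on the carbonyl carbon gives the smallest loss seen so far (a 3.6-fold higher number from compound 1 to compound 4 (0.55 log units; beyond the scatter)), so the cost of replacing (2-(dimethylamino)ethyl)amino depends strongly on what enters. The other two replacements fall behind it (a 3.8-fold lower number from compound 2 to compound 4 (0.58 log units; beyond the scatter); a 9.2-fold lower number from compound 3 to compound 4 (0.96 log units; beyond the scatter)), although no replacement matches compound 1. No supporting data bear on the reason for these differences.

Compound 4 changes the amide hydrogen and the chain end together, leaving their separate contributions open. A 2-hydroxyethylamino group, or a longer chain ending in a dimethylamino group, could help to separate them.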